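Replacing the fluorobenzyl on nitrogen with a butyl chain

The source may report more compounds than this note shows. Statements on the series, on what has been measured and on what is new or still open speak of the compounds shown alone.

Compound 1 `CCOC(=O)c1ccc(-c2nn(Cc3ccccc3F)c3ccccc23)cc1`: > 10000 nM in a functional assay on cells (Platelet, Homo sapiens) for inhibition; on this read-out higher numbers stand for weaker inhibition and lower numbers for stronger inhibition
Compound 2 `CCOC(=O)c1ccc(-c2nn(CC)c3ccccc23)cc1`: > 10000 nM
Compound 3 `CCOC(=O)c1ccc(-c2nn(C(C)C)c3ccccc23)cc1`: > 10000 nM

The three compounds share one core and differ only in the group carried on the aromatic nitrogen. The value of compound 1 is a limit of the assay, not a number. The value of compound 2 is likewise a limit. The value of compound 3 is likewise a limit. Compound 1 therefore stands at the limit, and the two further values sit at the same place, as the limit of > 10000 nM in this assay, at which 3 of the 3 values shown sit, records.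

Compound 4 `CCCCn1nc(-c2ccc(C(=O)OCC)cc2)c2ccccc21` has not yet been measured. Its change from compound 1 is propyl in place of 2-fluorophenyl on a saturated chain carbon bound to an aromatic nitrogen; the chain grows while the aromatic ring is lost, as in the move to the smaller ethyl and isopropyl groups already measured. Going by the values given here, the steps that bear on it are a step that the two limits leave unreadable from compound 1 to compound 2 and a step that the two limits leave unreadable from compound 1 to compound 3, whose sizes cannot be read because of the limit of > 10000 nM in this assay, at which 3 of the 3 values shown sit. With every measured neighbour at the limit, no direction of change can be drawn, and no step beyond the scatter is expected in this assay.

Compound 4 is therefore expected to remain at the limit as well, estimated at 20000 nM with a range from 8000 nM to 100000 nM. The expected step is a step that the limit leaves unreadable from compound 1 to compound 4.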

Compound 4, half-maximal inhibitory concentration: > 10000 nM
Compound 4 was reported as a limit; the forecaster's own chance of this, stated with the estimate: 85%; the middle value lies beyond the limit too.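

In this assay compound 4 gives > 10000 nM, which is a limit and not a number. Its steps from compound 1, compound 2 and compound 3 cannot be read, because all the values sit at the same limit: the limit of > 10000 nM in this assay, at which 4 of the 4 values shown sit.

The compounds shown leave open whether any group on the aromatic nitrogen of this shared core gives a measurable inhibition.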